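The compounds below may be only part of what the source reports. "The series", "measured", "known", "first", "only" and "open" are said of these compounds alone.

Compound 2 `O=C(Cc1cccnc1)c1cc2ccccc2[nH]1` in an in vitro assay on P815B cells for inhibition of Indoleamine 2,3-dioxygenase 1 (Mus musculus), tested at 20 uM (on this read-out higher numbers stand for more inhibition at the one concentration tested (going by the name of the read-out) and lower numbers for less inhibition), gives 13%, and compound 1 `O=C(Cc1cccnc1)c1cc2c(F)cccc2[nH]1` in this assay gives 12%, the step of a number 1 percentage points higher from compound 1 to compound 2 (within the scatter), so the two stand together at low inhibition. Compound 3 `Cn1c(C(=O)Cc2cccnc2)cc2ccccc21` differs from compound 2 by methyl in place of hydrogen on an aromatic nitrogen. Among the measured compounds shown here, no measured step touches that position: the one step known concerns hydrogen in place of fluoro on an aromatic carbon and gives no guide here. With both numbers low, no change beyond the scatter is expected for compound 3 in this assay, an estimated step of a number 3 percentage points lower from compound 2 to compound 3 (within the scatter). Compound 3 is estimated at 10%, range -8% to 28%.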

Compound 3, a percentage reported as inhibition, at one concentration (the size of the read-out at that concentration, not a potency): "not active" (no number reported)
Compound 3 has no reported number here; the estimate stays without a comparison.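

In this assay, among the compounds shown here, compound 3 is reported only as "not active", without a number, so no step from compound 2 can be read. Nothing on hand bears on this result. As far as these compounds go, the size of any effect of methyl in place of hydrogen on the aromatic nitrogen stays open.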